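Adding a Second Methoxy Group to Compound 2

This account rests on a few compounds, and the source may have more. Where it says the series, first, only, none or still open, it means among the compounds named here.

Among the compounds with values here, compound 2 `COc1ccc(Nc2nc(SCc3ccc(C(F)(F)F)cc3)nc3ccccc23)cc1` is the only compound here with a measured number: in a functional assay on HGC-27 cells (Homo sapiens) for cytotoxicity, read by MTT assay, with a stated time of 72 h (on this read-out lower numbers stand for stronger inhibition and higher numbers for weaker inhibition), compound 2 gives 23500 nM. Compound 1 `FC(F)(F)c1ccc(CSc2nc(Nc3ccccc3C(F)(F)F)c3ccccc3n2)cc1` carries a 2-(trifluoromethyl)phenyl on the same nitrogen. In this assay compound 1 reaches only a limit of > 50000 nM. Within the data shown here, the one measured step, an at least 2.1-fold lower number from compound 1 to compound 2 (0.32 log units; beyond the scatter), is open-ended because compound 1 sits at the limit of > 50000 nM in this assay, at which 1 of the 2 values shown sits. Compound 3 `COc1ccc(Nc2nc(SCc3ccc(C(F)(F)F)cc3)nc3ccccc23)c(OC)c1` differs from compound 2 by methoxy in place of hydrogen on an aromatic carbon, a methoxy in place of hydrogen on an aromatic carbon, ortho to a large group and meta to a methoxy group. That measured step exchanges one ring for another and does not add a group to a ring already present, so it does not bear directly on this change. In this assay the step from compound 2 is expected to be a 1.2-fold lower number from compound 2 to compound 3 (0.07 log units; within the scatter), nothing beyond the scatter. Compound 3 is estimated at 20000 nM, within 6000 nM to 60000 nM.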

Compound 3, half-maximal inhibitory concentration: > 50000 nM
Compound 3 ended at the assay's limit; the forecaster's own chance of this, stated with the estimate: 30%; middle value at least 2.5-fold (0.39 log units) away from the limit.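

In this assay, going from 4-methoxyphenyl to 2,4-dimethoxyphenyl on the nitrogen gives an at least 2.1-fold higher number from compound 2 to compound 3 (0.32 log units; beyond the scatter), so the added group weakens the compound instead of leaving the read-out unchanged. The earlier step exchanged one ring for another, whereas this one shows that a single methoxy group, ortho to a large group and meta to a methoxy group, is enough to move the number beyond the scatter. Compound 3 stands at a limit, as compound 1 does, so neither the full size of this loss nor the step between these two can be read: the limit of > 50000 nM in this assay, at which 2 of the 3 values shown sit.

Still open, from the compounds shown here alone, is whether a fluorine, a methyl or an amine at this position would weaken the compound in the same way. Also open, going by these compounds, is whether a methoxy group on another carbon of this ring would do so.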